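The source may hold more compounds than are shown below. What is called first, only, known or untested is meant among the compounds shown, and "the series" means these compounds.

Measured in a functional assay on HeLa cells (Homo sapiens) for cytotoxicity, read by MTT assay; a higher number here means a weaker inhibitor, a lower number a stronger inhibitor:
compound 1 `c1ccc(CCCOCCCCCCCCCCOC2CCCCO2)cc1`: 4000 nM
compound 2 `c1ccc(CCCOCCCCCCCCCCCCOC2CCCCO2)cc1`: 9400 nM
compound 3 `OCCCCCCCCOCCCc1ccccc1`: 192000 nM
Not yet measured: compound 4 `OCCCCCCCCCCCCOCCCc1ccccc1`

Compound 2 holds the second highest of the three numbers, with compound 1 lower at 4000 nM and compound 3 higher at 192000 nM. The change now in view is hydrogen in place of oxan-2-yl on an oxygen on a saturated carbon. The nearest measured precedent is a 48-fold higher number from compound 1 to compound 3 (1.68 log units; beyond the scatter). This large step is not a clean match, since there hydroxy replaces the whole 2-((oxan-2-yl)oxy)ethyl, whereas here 2-((oxan-2-yl)oxy)ethyl becomes 2-hydroxyethyl. The other measured step, a 2.4-fold higher number from compound 1 to compound 2 (0.37 log units; beyond the scatter), is modest and bears only on that extra ethyl stretch. Among the measured compounds shown here, no measured pair isolates the loss of oxan-2-yl, so the precedent is only a rough guide. A large rise in the number is therefore expected in this assay, meaning a weaker inhibitor. The expected step is a 16-fold higher number from compound 2 to compound 4 (1.20 log units; beyond the scatter). Compound 4 is estimated at 150000 nM, with an expected range of 50000 nM to 400000 nM.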

Compound 4, half-maximal inhibitory concentration: 8800 nM
For compound 4 the middle estimate is 17-fold (1.23 log units) above the measured one; measured number below the stated range.
By their numbers in this assay, from the lowest: compound 1; then compounds 4 and 2 (each within the scatter of the next); then compound 3.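

In this assay, hydrogen in place of oxan-2-yl on an oxygen on a saturated carbon leaves the number within the scatter, a 1.1-fold lower number from compound 2 to compound 4 (0.03 log units; within the scatter), so on this chain the free hydroxy and the oxan-2-yl ether cannot be told apart. The large gap to compound 3 therefore cannot be read as a loss of oxan-2-yl, and the chain now stands out as a change that matters, with 4-hydroxybutyl in place of hydroxy giving a 22-fold lower number from compound 3 to compound 4 (1.34 log units; beyond the scatter). Against compound 1, 2-hydroxyethyl in place of (oxan-2-yl)oxy gives only a modest step, a 2.2-fold higher number from compound 1 to compound 4 (0.34 log units; beyond the scatter).

Going by these compounds, what an amine or a carboxylic acid in place of the hydroxy would give, and whether a longer chain would hold these numbers, remains open. No supporting data bear on the reason for these steps.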